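Aryl swap on the piperazine of the shared core

This account rests on a few compounds, and the source may have more. Where it says the series, first, only, none or still open, it means among the compounds named here.

Measured so far in an assay on HEK293 cells for inhibition of Voltage-dependent T-type calcium channel subunit alpha-1G (Homo sapiens), read by fluorescence, tested at 10 uM; on this read-out lower numbers stand for less inhibition and higher numbers for more inhibition at the one concentration tested (going by the name of the read-out):
compound 1, `CCCc1nc(-c2ccccc2)c(CNCCN2CCN(c3ccc(C)cc3)CC2)o1`, 48.1%
compound 2, `CCCc1nc(-c2ccccc2)c(CNCCN2CCN(c3ccc(C(F)(F)F)cc3)CC2)o1`, 58.7%

Compound 2 stands highest of the two numbers, with compound 1 nearest at a number 10.6 percentage points higher from compound 1 to compound 2 (beyond the scatter). Compound 3, `CCCc1nc(-c2ccccc2)c(CNCCN2CCN(c3cccc(C)c3C)CC2)o1`, differs from compound 2 by 2,3-dimethylphenyl in place of 4-(trifluoromethyl)phenyl on an amine nitrogen in a ring. Among the measured compounds shown here, only the step from compound 1 to compound 2 bears on this change, and it was modest; with trifluoromethyl leaving and methyl returning, a step back toward the number of compound 1 is expected, giving a number 10.7 percentage points lower from compound 2 to compound 3 (beyond the scatter). Compound 3 is therefore estimated at 48%, within 30% to 65%.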

Compound 3, a percentage reported as inhibition, at one concentration (the size of the read-out at that concentration, not a potency): 66.7%
For compound 3 the middle estimate is 18.7 percentage points below the measured one; the whole stated range lies below it.
By their numbers in this assay, from the lowest: compound 1; then compounds 2 and 3 (each within the scatter of the next).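

In this assay, the methyl-only 2,3-dimethylphenyl does not return to the level of compound 1, so a methyl substituent alone does not set the read-out at this position: replacing 4-methylphenyl gives a number 18.6 percentage points higher from compound 1 to compound 3 (beyond the scatter). Replacing 4-(trifluoromethyl)phenyl gives a number 8 percentage points higher from compound 2 to compound 3 (within the scatter), so trifluoromethyl is not needed to reach the range of compound 2. Nothing available accounts for these steps.

Open, going by these compounds, is whether 2-methylphenyl or 3-methylphenyl alone would give the step seen with 2,3-dimethylphenyl. On these data alone, how 4-chlorophenyl or 4-methoxyphenyl would read at this position also remains open.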